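Amide terminus variation in a malonamide series

The source may report more compounds than this note shows. Statements on the series, on what has been measured and on what is new or still open speak of the compounds shown alone.

In a functional assay on the whole organism for inhibition, with Cavia porcellus as the target (a higher number here means that more compound is needed for the effect, a lower number that less compound is needed), compound 1 `CCOC(=O)CC(=O)N1CCSC1COc1ccccc1OC` gives 21 mg/kg and compound 2 `CNC(=O)CC(=O)N1CCSC1COc1ccccc1OC` gives 21 mg/kg. Compound 3 `COc1ccccc1OCC1SCCN1C(=O)CC(=O)N1CCN(C)CC1` gives 27 mg/kg in this assay, the highest of the three numbers, although a 1.3-fold higher number from compound 1 to compound 3 (0.11 log units; within the scatter) and a 1.3-fold higher number from compound 2 to compound 3 (0.11 log units; within the scatter) both stay within the scatter, as does no change at the digits printed from compound 1 to compound 2 (within the scatter).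

Compound 4 `COc1ccccc1OCC1SCCN1C(=O)CC(=O)NCc1ccncc1` differs from compound 3 in one place: ((pyridin-4-yl)methyl)amino in place of 4-methylpiperazin-1-yl on a carbonyl carbon. All three measured steps exchange the group on this same carbonyl carbon, and none of them moved the dose beyond the scatter, so for compound 4 no step beyond the scatter is expected in this assay: a 1.1-fold lower number from compound 3 to compound 4 (0.05 log units; within the scatter). The dose for compound 4 is estimated at 24 mg/kg, with a range from 12 mg/kg to 48 mg/kg.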

Compound 4, dose for half-maximal effect: 23 mg/kg
Compound 4: the middle estimate sits 1.0-fold (0.02 log units) above what was measured, within the range that was stated.
By their numbers in this assay, from the lowest: compounds 1, 2, 4 and 3 (each within the scatter of the next).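

With ((pyridin-4-yl)methyl)amino on the carbonyl carbon, a six-membered aromatic ring now stands at this place, and this assay still shows no step beyond the scatter (a 1.2-fold lower number from compound 3 to compound 4 (0.07 log units; within the scatter)). The same holds with pyridin-4-yl in place of hydrogen on the saturated chain carbon (a 1.1-fold higher number from compound 2 to compound 4 (0.04 log units; within the scatter)) and for the exchange with ethoxy (a 1.1-fold higher number from compound 1 to compound 4 (0.04 log units; within the scatter)). No evidence is available on what lies behind this insensitivity.

On these data alone, whether a carboxylic acid or a longer alkyl chain at this carbonyl carbon also stays within the scatter remains open. So does whether changes on the core of compound 1 would move the dose.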